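Removing the trifluoromethyl and chloro groups from the urea partner

The source may report more compounds than this note shows. Statements on the series, on what has been measured and on what is new or still open speak of the compounds shown alone.

Three compounds share one core and differ only in the group attached to the carbonyl carbon of an amide-type nitrogen. Compound 1 `COc1cc(-c2nn(-c3cccc(NC(=O)c4cccc(C(F)(F)F)c4)c3)cc2-c2ccncc2)ccc1Cl` carries a 3-(trifluoromethyl)phenyl there and in a functional assay on K562 cells (Homo sapiens) for inhibition, read by sulforhodamine B assay, with a stated time of 48 h (a lower number here means a stronger inhibitor of growth, a higher number a weaker inhibitor of growth), compound 1 gives 1400 nM. Compound 2 `COc1cc(-c2nn(-c3cccc(NC(=O)c4ccc(Cl)c(C(F)(F)F)c4)c3)cc2-c2ccncc2)ccc1Cl` adds a chloro on the same ring, and in this assay compound 2 gives 1610 nM. Compound 3 `COc1cc(-c2nn(-c3cccc(NC(=O)Nc4ccc(Cl)c(C(F)(F)F)c4)c3)cc2-c2ccncc2)ccc1Cl` links that chlorinated ring through a further nitrogen, and in this assay compound 3 gives 1210 nM, the lowest of the three numbers, though every gap to the others lies within the scatter: a 1.2-fold higher number from compound 1 to compound 2 (0.06 log units; within the scatter), a 1.2-fold lower number from compound 1 to compound 3 (0.06 log units; within the scatter) and a 1.3-fold lower number from compound 2 to compound 3 (0.12 log units; within the scatter).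

Compound 4 `COc1cc(-c2nn(-c3cccc(NC(=O)c4ccccc4)c3)cc2-c2ccncc2)ccc1Cl` is the next step from compound 3: phenyl in place of (4-chloro-3-(trifluoromethyl)phenyl)amino on a carbonyl carbon. This strips away the extra nitrogen, the trifluoromethyl and the chloro at once. Within the data shown here, none of the measured steps removed so much; they only show that small changes on this ring left the number where it was. Among the measured compounds shown here, with no direct precedent, the expectation for the step from compound 3 to compound 4 in this assay is a modest rise in the number, a 1.8-fold higher number from compound 3 to compound 4 (0.26 log units; within the scatter), carrying real uncertainty. For compound 4 the estimated value in this assay is 2200 nM, with a range from 800 nM to 6500 nM.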

Compound 4, concentration for 50% growth inhibition: 421 nM
Beside the measured number, compound 4's estimate is 5.2-fold (0.72 log units) above it; the whole stated range lies above it.
By their numbers in this assay, from the lowest: compound 4; then compounds 3, 1 and 2 (each within the scatter of the next).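

Up to now, changes at this position left the number in place, so the ring on the carbonyl carbon could have seemed free to vary without consequence in this assay. Among these compounds, the plain phenyl shows otherwise: it gives the first steps beyond the scatter, both from the urea (a 2.9-fold lower number from compound 3 to compound 4 (0.46 log units; beyond the scatter)) and from the chlorinated amide (a 3.8-fold lower number from compound 2 to compound 4 (0.58 log units; beyond the scatter)), making compound 4 the strongest inhibitor of growth of the four. The simplest comparison is the single swap of hydrogen for trifluoromethyl (a 3.3-fold lower number from compound 1 to compound 4 (0.52 log units; beyond the scatter)), which shows that losing the trifluoromethyl alone is enough to lower the number, although nothing shown explains why the smaller group does better.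

The compounds shown leave open whether the gain needs a completely bare ring, or whether a small group such as fluoro, methyl or methoxy in place of the trifluoromethyl would keep it. They also leave open whether a urea carrying a plain phenyl would match compound 4, which would test the extra nitrogen apart from the ring's substituents.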